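The source may report more compounds than this note shows. Statements on the series, on what has been measured and on what is new or still open speak of the compounds shown alone.

Measured in a functional assay on MCF7 cells (Homo sapiens) for antiproliferative activity; a lower number here means a stronger inhibitor, a higher number a weaker inhibitor:
- compound 1 `CC(C)=CCc1cc(C(=O)Nc2cc3ccc(OCC4CCN(C)C4)c(C)c3oc2=O)ccc1O` gives 1550 nM
- compound 2 `CC(C)=CCc1cc(C(=O)Nc2cc3ccc(OCCCNC(C)C)c(C)c3oc2=O)ccc1O` gives 740 nM
- compound 3 `CC(C)=CCc1cc(C(=O)Nc2cc3ccc(OCCCN(C(C)C)C(C)C)c(C)c3oc2=O)ccc1O` gives 1310 nM

Compound 3, at 1310 nM, is within the scatter of both neighbours: the data show a 1.2-fold lower number from compound 1 to compound 3 (0.07 log units; within the scatter) and a 1.8-fold higher number from compound 2 to compound 3 (0.25 log units; within the scatter). Compound 4 `CC(C)=CCc1cc(C(=O)Nc2cc3ccc(OCCCNC4CCCCC4)c(C)c3oc2=O)ccc1O` makes one change to compound 3: cyclohexylamino in place of diisopropylamino on a saturated chain carbon, three bonds along the chain from an oxygen on an aromatic ring. In words, cyclohexylamino replaces diisopropylamino, so the amine regains a hydrogen, as in compound 2.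

The closest guide is the step between compound 2 and compound 3, where an isopropyl replaces that hydrogen, and it stayed small at a 1.8-fold higher number from compound 2 to compound 3 (0.25 log units; within the scatter). The step of a 2.1-fold lower number from compound 1 to compound 2 (0.32 log units; beyond the scatter) is modest and shows that the amine end can shift the number a little. Going by the values given here, no measured compound carries a cyclohexyl ring, so this part remains untested. A small move to a lower number is therefore expected, with no step beyond the scatter. The expected change is a 1.6-fold lower number from compound 3 to compound 4 (0.21 log units; within the scatter). For compound 4 the estimated value is 800 nM, with an expected range of 350 nM to 1800 nM.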

Compound 4, half-maximal inhibitory concentration: 1070 nM
For compound 4 the middle estimate is 1.3-fold (0.13 log units) below the measured one; measured number inside the range.
By their numbers in this assay, from the lowest: compounds 2, 4, 3 and 1 (each within the scatter of the next, the first and the last beyond it).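

In this assay, this position now accepts a ring on the amine nitrogen: cyclohexylamino in place of diisopropylamino brings a ring and a hydrogen-bond donor at the same heavy-atom count, yet a 1.2-fold lower number from compound 3 to compound 4 (0.09 log units; within the scatter) stays within the scatter. Cyclohexyl in place of isopropyl on the amine nitrogen gives a 1.4-fold higher number from compound 2 to compound 4 (0.16 log units; within the scatter), and replacing the 1-methylpyrrolidin-3-yl group gives a 1.4-fold lower number from compound 1 to compound 4 (0.16 log units; within the scatter), so both of these changes also stay within the scatter. No measurement at hand explains why these different amine ends give such similar numbers.

Still open, going by these compounds, is whether a primary amine, a morpholine ring or a benzylamino group at the chain end would move the number beyond the scatter. A chain longer than 3-(cyclohexylamino)propyl also remains to be compared.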